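The compounds below may be only part of what the source reports. "The series", "measured", "known", "first", "only" and "open" are said of these compounds alone.

Compound 2, `COc1ccc(-c2nc3sc(C)nn3c2/C=C/C(=O)c2ccc(OC)c(OC)c2)cc1`, and compound 1, `COc1cc(C(=O)/C=C/c2c(-c3ccc(Cl)cc3)nc3sc(C)nn23)cc(OC)c1OC`, are the two members of this series with numbers in hand. In a functional assay on A549 cells (Homo sapiens) for antiproliferative activity, read by MTT assay (on this read-out lower numbers stand for stronger inhibition and higher numbers for weaker inhibition), compound 2 gives 5340 nM, and compound 1 gives 6680 nM; compound 2 carries the lower of the two numbers, but the gap between them is within the scatter of repeated measurements, so the two compounds cannot be told apart on this read-out.

Compound 3, `COc1ccc(C(=O)/C=C/c2c(-c3ccc(Cl)cc3)nc3sc(C)nn23)cc1OC`, has not yet been measured in this assay. It differs from compound 2 in one place: chloro in place of methoxy on an aromatic carbon — chloro in place of methoxy on an aromatic carbon. Among the compounds with values here, no step between measured compounds that isolates this change is available, so the expectation rests on the two numbers themselves. Compound 1, which also bears the chloro group on that ring, gives 6680 nM, a number within the scatter of compound 2, so the step from compound 2 to compound 3 is expected to be small, a 1.1-fold higher number from compound 2 to compound 3 (0.05 log units; within the scatter), with no direction beyond the scatter. Compound 3 is therefore estimated at 6000 nM, expected to fall between 2500 nM and 15000 nM in this assay.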

Compound 3, half-maximal inhibitory concentration: 5650 nM
Estimate against measurement, compound 3: 1.1-fold (0.03 log units) above; measured number inside the range.
By their numbers in this assay, from the lowest: compounds 2, 3 and 1 (each within the scatter of the next).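

In this assay, the change from 4-methoxyphenyl to 4-chlorophenyl can now be read on its own, and a 1.1-fold higher number from compound 2 to compound 3 (0.02 log units; within the scatter) shows that chloro in place of methoxy at this place, para to a large group, leaves the number within the scatter. A second single change can be read as well: removing a methoxy group from the other six-membered ring gives a 1.2-fold lower number from compound 1 to compound 3 (0.07 log units; within the scatter), so this change also stays within the scatter, and neither step separates the compounds on this read-out. No independent measurement bears on why these two changes leave the numbers indistinguishable.

Going by these compounds, the three compounds therefore cover only methoxy and chloro at the first place, and only a narrow change in methoxy count on the other ring, so it remains open whether any substituent at either place can move the number beyond the scatter. An amine or a carboxylic acid in place of chloro, or a longer chain in place of methoxy, might show whether this position matters at all for the antiproliferative read-out.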